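The source may hold more compounds than are shown below. What is called first, only, known or untested is meant among the compounds shown, and "the series" means these compounds.

For the measured compounds named here, in a physicochemical assay for lipophilicity (on this read-out higher numbers stand for higher lipophilicity and lower numbers for lower lipophilicity), three compounds have numbers so far. Compound 1 `CCCCCCN(CCCCCSc1nc2cc([N+](=O)[O-])ccc2[nH]1)C(=O)Nc1ccc(F)cc1F` gives 7.19, compound 2 `CCCCCCN(CCCCCSc1nc2c[nH]cnc-2n1)C(=O)Nc1ccc(F)cc1F` gives 5.26, and compound 3 `CCCCCCCN(CCCCCSc1nc(O)c2ccccc2n1)C(=O)Nc1ccc(F)cc1F` gives 6.17, which places compound 3 in the middle of the three.

The next compound, compound 4 `CCCCCCCN(CCCCCSc1nc(N)c2c[nH]nc2n1)C(=O)Nc1ccc(F)cc1F`, has not been measured. It matches compound 3 except for the group on the sulfur: a group of 10 heavy atoms (5 carbon, 5 nitrogen; one five-membered aromatic ring with 2 hetero atoms, one six-membered aromatic ring with 2 hetero atoms) in place of a group of 11 heavy atoms (8 carbon, 2 nitrogen, 1 oxygen; one six-membered aromatic ring of carbon only, one six-membered aromatic ring with 2 hetero atoms), on a sulfur.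

Going by the values given here, one measured step bears on this change. It is also a swap of the group on a sulfur, a number 1.93 log units lower from compound 1 to compound 2 (beyond the scatter), and it is large and beyond the scatter. In that swap, as here, the entering group is smaller and holds no oxygen. However, its leaving group is not the one in compound 3, and a single step indicates direction better than size. A fall is therefore expected, but a smaller one than that single step, and the expected change is a number 0.87 log units lower from compound 3 to compound 4 (beyond the scatter). For compound 4 the estimated value is 5.3, with an expected range from 4.6 to 5.9.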

Compound 4, partition coefficient: 5.74
Estimate against measurement, compound 4: 0.44 log units below, within the range that was stated.
By their numbers in this assay, from the lowest: compound 2; then compound 4; then compound 3; then compound 1.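

At the sulfur, replacing 4-hydroxyquinazolin-2-yl with the nitrogen-rich group of compound 4 gives in this assay a number 0.43 log units lower from compound 3 to compound 4 (beyond the scatter) and so adds a second swap at this position that lowers the number. That step is modest, whereas a number 1.93 log units lower from compound 1 to compound 2 (beyond the scatter) is large, so the two swaps agree in direction but not in size, and they involve different leaving groups, entering groups and chains. No measurement shown accounts for the size of either step.

In compound 4, the ring system, the oxygen and the hydrogen-bond donor and acceptor counts all change together, so the compounds shown cannot assign the fall to any one of these changes. As far as these compounds go, whether a phenyl group or a carboxylic acid on the sulfur-bound group would also lower the number remains open.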